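Replacing a chlorophenyl with a nitrophenyl on the sulfonamide

The source may report more compounds than this note shows. Statements on the series, on what has been measured and on what is new or still open speak of the compounds shown alone.

Compound 1 `CCCCc1ccc(S(=O)(=O)NCCCCCCNCc2ccc(Br)cc2)cc1` gives 5700 nM in a functional assay on MIA PaCa-2 cells (Homo sapiens) for inhibition, read by MTT assay, with a stated time of 72 h; a higher number here means a weaker inhibitor of growth, a lower number a stronger inhibitor of growth.
Compound 2 `O=S(=O)(NCCCCCCNCc1ccc(Br)cc1)c1ccccc1F` gives 13300 nM in this assay.
Compound 3 `O=S(=O)(NCCCCCCNCc1ccc(Br)cc1)c1ccc(Cl)cc1` gives 5900 nM in this assay.

Compound 3 has the second highest of the three numbers; compound 1 is within the scatter of it, while compound 2 gives a higher number beyond the scatter. The step to compound 4 `O=[N+]([O-])c1ccccc1S(=O)(=O)NCCCCCCNCc1ccc(Br)cc1` is 2-nitrophenyl in place of 4-chlorophenyl on a sulfonyl sulfur. Among the compounds with values here, two measured steps bear on it: a 1.0-fold higher number from compound 1 to compound 3 (0.01 log units; within the scatter) and a 2.3-fold lower number from compound 2 to compound 3 (0.35 log units; beyond the scatter). The first shows that swapping the group at the same position changes little; the second shows that a 2-fluorophenyl gives a weaker result than a 4-chlorophenyl. Since compound 4 also carries a substituent in the 2-position, a modest rise is expected, a 2.0-fold higher number from compound 3 to compound 4 (0.31 log units; beyond the scatter), giving compound 4 an estimated 12000 nM within 5000 nM to 30000 nM.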

Compound 4, concentration for 50% growth inhibition: 11700 nM
For compound 4 the middle estimate is 1.0-fold (0.01 log units) above the measured one; measured number inside the range.
By their numbers in this assay, from the lowest: compounds 1, 3, 4 and 2 (each within the scatter of the next, the first and the last beyond it).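

With nitro in place of fluoro on the aromatic carbon, the number barely moves: a 1.1-fold lower number from compound 2 to compound 4 (0.06 log units; within the scatter). The other step, a 2.0-fold higher number from compound 3 to compound 4 (0.30 log units; within the scatter), also stays within the scatter, so compound 4 cannot be clearly separated from either compound 2 or compound 3, although those two differ beyond the scatter. No measurement here explains these numbers. On these data alone, it remains open whether an amine or a carboxylic acid in place of the nitro would also leave the number unchanged.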